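The compounds below may be only part of what the source reports. "The series", "measured", "known", "first", "only" and "open" are said of these compounds alone.

In a physicochemical assay for solubility, with a stated time of 18 h, at pH 7.4 (a lower number here means a less soluble compound, a higher number a more soluble compound), compound 1 `COc1ccc(-c2ccc3c(NCCCNCc4cc(F)ccc4OC)ccnc3c2)cc1` gives 32000 nM and compound 2 `COc1ccc(F)cc1CNCCCNc1ccnc2cc(Cc3cccc(C(F)(F)F)c3)ccc12` gives 4200 nM while compound 3 `COc1ccc(F)cc1CNCCCNc1ccnc2cc(CC3CCCCC3)ccc12` gives 4200 nM in the same test. Compound 3 is therefore level with compound 2, and together they hold the lowest of the three numbers. Compound 4 `COc1ccc(F)cc1CNCCCNc1ccnc2cc(-c3ccc(C(F)(F)F)cc3)ccc12` differs from compound 3 by a single change, 4-(trifluoromethyl)phenyl in place of cyclohexylmethyl on an aromatic carbon in short 4-(trifluoromethyl)phenyl in place of cyclohexylmethyl on an aromatic carbon. Among the compounds with values here, three measured steps bear on it. Leaving 4-methoxyphenyl gave a 7.6-fold lower number from compound 1 to compound 2 (0.88 log units; beyond the scatter) with 3-(trifluoromethyl)benzyl and a 7.6-fold lower number from compound 1 to compound 3 (0.88 log units; beyond the scatter) with cyclohexylmethyl, both modest in size, while no change at the digits printed from compound 2 to compound 3 (within the scatter) separates those two groups not at all. Compound 4 keeps a phenyl ring on that carbon like compound 1 at 32000 nM but also carries trifluoromethyl like compound 2 at 4200 nM so its number could lie near either. The expected step in this assay is small and upward: a 1.4-fold higher number from compound 3 to compound 4 (0.15 log units; within the scatter) by this estimate. For compound 4 the estimate is 6000 nM with an expected range of 1500 nM to 25000 nM for a measurement.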

Compound 4, solubility: 32000 nM
Beside the measured number, compound 4's estimate is 5.3-fold (0.73 log units) below it, and the stated range ends below it.
By their numbers in this assay, from the lowest: compounds 2 and 3 (each within the scatter of the next); then compounds 1 and 4 (each within the scatter of the next).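

In this assay, 4-(trifluoromethyl)phenyl on this aromatic carbon gives a 7.6-fold higher number from compound 3 to compound 4 (0.88 log units; beyond the scatter) and a 7.6-fold higher number from compound 2 to compound 4 (0.88 log units; beyond the scatter), so carrying trifluoromethyl does not by itself bring the low number of compound 2. Trifluoromethyl in place of methoxy on the phenyl ring gives no change at the digits printed from compound 1 to compound 4 (within the scatter), so at this position the swap between these two groups leaves the number where it was. Across these four compounds the split therefore follows what is bound to the aromatic carbon: compounds 1 and 4, with an aromatic ring there, share the higher number, while compounds 2 and 3, with a saturated chain carbon there, share the lower one, and no compound here goes against this. Nothing measured here gives a reason for this split. Going by these compounds, whether a phenyl ring carrying a carboxylic acid or an amine, or a longer chain ending in a phenyl ring, would fit the same split remains open.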